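The source may report more compounds than this note shows. Statements on the series, on what has been measured and on what is new or still open speak of the compounds shown alone.

Measured so far in a functional assay on RPMI 8402 cells (Homo sapiens) for cytotoxicity; on this read-out lower numbers stand for stronger inhibition and higher numbers for weaker inhibition:
- Compound 1 `N#Cc1ccc2[nH]c(-c3ccc4[nH]c(-c5ccc6[nH]cnc6c5)nc4c3)nc2c1`: > 25000 nM (a limit)
- Compound 2 `c1ccc2[nH]c(-c3ccc4[nH]c(-c5ccc6[nH]cnc6c5)nc4c3)nc2c1`: 14000 nM

The entry for compound 1, > 25000 nM, is a limit and not a number. Among the measured compounds shown here, compound 2, at 14000 nM, therefore holds the only true number in this small set. Compound 3 `c1ccc(-c2ccc3[nH]c(-c4ccc5[nH]c(-c6ccc7[nH]cnc7c6)nc5c4)nc3c2)nc1` keeps the core of compound 2 and places pyridin-2-yl in place of hydrogen on an aromatic carbon. For the measured compounds named here, only one measured step bears on this change: an at least 1.7-fold lower number from compound 1 to compound 2 (0.25 log units; that floor lies within the scatter). It also concerns a group on an aromatic carbon, but it gives only a bound, and that bound lies within the scatter. It therefore sets neither the size nor the direction firmly. Compound 2, at 14000 nM, leaves wide room for a lower number, so a clear drop is expected, with broad uncertainty. The expected change is a 12-fold lower number from compound 2 to compound 3 (1.07 log units; beyond the scatter). For compound 3 the estimated value in this assay is 1200 nM, with an expected range of 150 nM to 10000 nM.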

Compound 3, half-maximal inhibitory concentration: 160 nM
Beside the measured number, compound 3's estimate is 7.5-fold (0.88 log units) above it; the measured number falls inside the stated range.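

In this assay, pyridin-2-yl in place of hydrogen on an aromatic carbon gives an 88-fold lower number from compound 2 to compound 3 (1.94 log units; beyond the scatter), so a change at this position can move the read-out far beyond the scatter, which the earlier step, with its bound inside the scatter, could not show. Set against the cyano group at the same place, pyridin-2-yl gives an at least 150-fold lower number from compound 1 to compound 3 (2.19 log units; beyond the scatter), and that size is only a floor. Compound 1 stands at a limit and not at a number: the limit of > 25000 nM in this assay, at which 1 of the 3 values shown sits.

The compounds shown hold only one ring at this position, so they cannot separate the effect of the ring from that of its nitrogen, a question that a plain phenyl group would address. They also leave open how an amine or a carboxylic acid at the same place would read.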